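Ethyl for methyl on the anilide side, second pairing

The source may report more compounds than this note shows. Statements on the series, on what has been measured and on what is new or still open speak of the compounds shown alone.

Compound 3 `CCNC(=O)Nc1cccc(S(=O)(=O)Nc2ccccc2C)c1` is the weakest-reading member of the measured trio: in a functional assay on HT-29 cells (Homo sapiens) for cytotoxicity, read by sulforhodamine B assay, with a stated time of 48 h (on this read-out lower numbers stand for stronger inhibition and higher numbers for weaker inhibition), compound 3 gives 102000 nM, the highest of the three numbers. Compound 2 `CCc1ccccc1NS(=O)(=O)c1cccc(NC(=O)NCCCCl)c1` gives 96000 nM, a number within the scatter of that of compound 3, so the two cannot be ordered. Compound 1 `Cc1ccccc1NS(=O)(=O)c1cccc(NC(=O)NCCCCl)c1` gives 42000 nM; the two measured steps from it are a 2.4-fold higher number from compound 1 to compound 3 (0.39 log units; beyond the scatter) and a 2.3-fold higher number from compound 1 to compound 2 (0.36 log units; beyond the scatter), both modest and both in the direction of a higher number.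

Compound 4 `CCNC(=O)Nc1cccc(S(=O)(=O)Nc2ccccc2CC)c1` is not yet measured. It differs from compound 3 by methyl in place of hydrogen on a saturated chain carbon bound to an aromatic carbon. Within the data shown here, one measured step bears on this directly: the identical change, made on compound 1, gave a 2.3-fold higher number from compound 1 to compound 2 (0.36 log units; beyond the scatter). The step of a 2.4-fold higher number from compound 1 to compound 3 (0.39 log units; beyond the scatter) concerns a different part of the molecule and says nothing about the methyl, but it confirms that changes in this set move the numbers by modest amounts only.

A step of about the same size and direction is therefore expected, a 2.3-fold higher number from compound 3 to compound 4 (0.35 log units; beyond the scatter), in this assay. Compound 4 is accordingly estimated at 230000 nM, with a range from 100000 nM to 520000 nM. At numbers this high the assay may report only a limit rather than a value.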

Compound 4, half-maximal inhibitory concentration: 15000 nM
Compound 4: the middle estimate sits 15-fold (1.19 log units) above what was measured, and the stated range ends above it.
By their numbers in this assay, from the lowest: compound 4; then compound 1; then compounds 2 and 3 (each within the scatter of the next).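

In this assay, methyl in place of hydrogen on a saturated chain carbon bound to an aromatic carbon has no fixed direction of its own: on the core of compound 3 it gives a 6.8-fold lower number from compound 3 to compound 4 (0.83 log units; beyond the scatter), the reverse of its direction on the core of compound 1: the same change on two cores in this assay, a 2.3-fold higher number (0.36 log units; beyond the scatter) from compound 1 to compound 2 and a 6.8-fold lower number (0.83 log units; beyond the scatter) from compound 3 to compound 4, 16-fold (1.19 log units) apart, beyond the scatter of two such steps

Hydrogen in place of chloromethyl on a saturated chain carbon, two bonds along the chain from an amide-type nitrogen, reverses in the same way, giving a 6.4-fold lower number from compound 2 to compound 4 (0.81 log units; beyond the scatter) once the 2-ethylphenyl group is present: the same change on two cores in this assay, a 2.4-fold higher number (0.39 log units; beyond the scatter) from compound 1 to compound 3 and a 6.4-fold lower number (0.81 log units; beyond the scatter) from compound 2 to compound 4, 16-fold (1.19 log units) apart, beyond the scatter of two such steps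

The two changes therefore cannot be treated as independent in this series: each raises the number on the core of compound 1, and each lowers it once the other is in place.

From the compounds shown here alone, how far this reversal extends remains open, including whether a propyl or a methoxy group in place of the ethyl on the 2-ethylphenyl group of compound 4 keeps the lower number, and whether a longer chain at the other end does the same. Why the two changes depend on each other also remains open, and the reversal rests on a single set of four compounds.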